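This account rests on a few compounds, and the source may have more. Where it says the series, first, only, none or still open, it means among the compounds named here.

Compound 1 `CCOC(=O)NC(=O)NC1=CS(=O)(=O)O[C@@]12[C@@H](CO[Si](C)(C)C(C)(C)C)O[C@@H](n1cc(C)c(=O)n(C)c1=O)[C@@H]2O[Si](C)(C)C(C)(C)C` gives 14000 nM in a functional assay on HEL cells (Homo sapiens) (on this read-out lower numbers stand for higher toxicity in this test and higher numbers for lower toxicity in this test), the highest of the two numbers measured there. Compound 3 `CCOC(=O)CNC(=O)NC1=CS(=O)(=O)O[C@@]12[C@@H](CO[Si](C)(C)C(C)(C)C)O[C@@H](n1cc(C)c(=O)n(C)c1=O)[C@@H]2O[Si](C)(C)C(C)(C)C` gives 13000 nM in this assay, and there is a 1.1-fold lower number from compound 1 to compound 3 (0.03 log units; within the scatter). Compound 2 `CC(=O)NC1=CS(=O)(=O)O[C@@]12[C@@H](CO[Si](C)(C)C(C)(C)C)O[C@@H](n1cc(C)c(=O)n(C)c1=O)[C@@H]2O[Si](C)(C)C(C)(C)C` gives only a limit of the test, > 200000 nM. For compound 2 this is the limit of > 200000 nM in this assay, at which 1 of the 3 values shown sits. There is an at least 14-fold higher number from compound 1 to compound 2 (1.15 log units; beyond the scatter). Compound 4 `Cc1cn([C@@H]2O[C@H](CO[Si](C)(C)C(C)(C)C)[C@@]3(OS(=O)(=O)C=C3NCCC(=O)O)[C@H]2O[Si](C)(C)C(C)(C)C)c(=O)n(C)c1=O` differs from compound 1 by 2-carboxyethyl in place of (ethoxycarbonyl)carbamoyl on an amine nitrogen. Within the data shown here, of the measured steps, the one from compound 1 to compound 2 bears most on this change, as both remove the (ethoxycarbonyl)carbamoyl part, and it was large; the step from compound 1 to compound 3 was within the scatter. Compound 4 is therefore expected to show an 11-fold higher number from compound 1 to compound 4 (1.03 log units; beyond the scatter), with an estimated 150000 nM between 30000 nM and 400000 nM.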

Compound 4, half-maximal cytotoxic concentration: 34000 nM
Beside the measured number, compound 4's estimate is 4.4-fold (0.64 log units) above it, and the stated range covers the measured number.
By their numbers in this assay, from the lowest: compounds 3 and 1 (each within the scatter of the next); then compound 4. At a limit, above all of these: compound 2.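

In this assay, swapping the (ethoxycarbonyl)carbamoyl part on the amine nitrogen for 2-carboxyethyl does not reach the level of the acetyl group, giving only a 2.4-fold higher number from compound 1 to compound 4 (0.39 log units; beyond the scatter), while the ((ethoxycarbonyl)methyl)carbamoyl group gives a 2.6-fold higher number from compound 3 to compound 4 (0.42 log units; beyond the scatter). Acetyl on that nitrogen remains apart, with an at least 5.8-fold lower number from compound 2 to compound 4 (0.76 log units; beyond the scatter). Compound 2 stands at a limit of the test: the limit of > 200000 nM in this assay, at which 1 of the 4 values shown sits.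

On these data alone, whether the shift belongs to the carboxylic acid or to the chain stays open. The ethyl ester of 2-carboxyethyl, or a longer chain ending in a carboxylic acid, would separate the two.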